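A few compounds are considered here, and "the series" means these few. Any claim that something is new, unique, unknown or untested is made for them only; others in the source may bear on it.

Compound 1 `C=CCCCCCN=C=S` gives 1050 nM in an assay on TREx-HEK cells for activation of transient receptor potential cation channel subfamily A member 1 (Homo sapiens), read by calcium flux; a higher number here means that more compound is needed for the effect, a lower number that less compound is needed. Compound 2 `CSCCCCCN=C=S` gives 500 nM. Compound 3 `CSCCCCCCN=C=S` gives 580 nM.

On these numbers compound 3 sits close to compound 2, with a 1.2-fold higher number from compound 2 to compound 3 (0.06 log units; within the scatter), and somewhat apart from compound 1, with a 1.8-fold lower number from compound 1 to compound 3 (0.26 log units; within the scatter). Compound 4 `CSCCCCCCCN=C=S` differs from compound 3 by (methylsulfanyl)methyl in place of methylsulfanyl on a saturated chain carbon, six bonds along the chain from an amide-type nitrogen. For the measured compounds named here, the one measured step of the same kind, lengthening the chain by one carbon while keeping the methylsulfanyl end, is a 1.2-fold higher number from compound 2 to compound 3 (0.06 log units; within the scatter), which stayed within the scatter. The step from compound 3 to compound 4 is therefore expected to be no larger than that, in either direction: a 1.1-fold higher number from compound 3 to compound 4 (0.03 log units; within the scatter). Compound 4 is accordingly estimated at 620 nM, with a likely range from 310 nM to 1250 nM.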

Compound 4, half-maximal effective concentration: 610 nM
Compound 4: middle estimate off by 1.0-fold (0.01 log units), on the high side; low and high end bracket the measured number.
By their numbers in this assay, from the lowest: compounds 2, 3, 4 and 1 (each within the scatter of the next, the first and the last beyond it).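

Swapping methylsulfanyl for (methylsulfanyl)methyl at this place, six bonds along the chain from the amide-type nitrogen, makes no readable difference in this assay, with a 1.1-fold higher number from compound 3 to compound 4 (0.02 log units; within the scatter). The wider change to 2-(methylsulfanyl)ethyl also stays within the scatter, with a 1.2-fold higher number from compound 2 to compound 4 (0.09 log units; within the scatter), and so does the comparison with the vinyl compound, with a 1.7-fold lower number from compound 1 to compound 4 (0.24 log units; within the scatter). No supporting data explain this insensitivity to chain length.

A still longer chain could show whether this pattern continues. An amine or a carboxylic acid in place of methylsulfanyl could show whether the sulfur group itself matters.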